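This account rests on a few compounds, and the source may have more. Where it says the series, first, only, none or still open, it means among the compounds named here.

Compound 1 `COc1ccc2c(c1)OC(c1cc(OC)c(OC)c(OC)c1)C(C(=O)O)=C2` in a functional assay for inhibition of nuclear factor NF-kappa-B complex (Homo sapiens) (a lower number here means a stronger inhibitor, a higher number a weaker inhibitor), gives only a limit, > 50000 nM.
Compound 2 `COc1ccc2c(c1)OC(c1cc(OC)c(OC)c(OC)c1)C(/C=N/O)=C2` in this assay gives 14100 nM.

Among the compounds with values here, compound 2 thus holds the only number; the other result is a limit (the limit of > 50000 nM in this assay, at which 1 of the 2 values shown sits). Compound 3 `COc1ccc2c(c1)OC(c1cc(OC)c(OC)c(OC)c1)C(C(=O)N(C)C)=C2` differs from compound 2 by a group of 5 heavy atoms (3 carbon, 1 nitrogen, 1 oxygen; no ring) in place of a group of 3 heavy atoms (1 carbon, 1 nitrogen, 1 oxygen; no ring), on a double-bonded ring carbon. Within the data shown here, the single measured step, an at least 3.5-fold lower number from compound 1 to compound 2 (0.54 log units; beyond the scatter), exchanged a different group on the same double-bonded ring carbon and so bears only loosely on this change. In this assay a step of about a 1.4-fold higher number from compound 2 to compound 3 (0.15 log units; within the scatter) is expected, within the scatter. Compound 3 is estimated at 20000 nM, with a range from 5000 nM to 80000 nM.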

Compound 3, half-maximal inhibitory concentration: > 50000 nM
Compound 3: no number, only a limit; the forecaster's own chance of this, stated with the estimate: 35%; at least 2.5-fold (0.39 log units) between middle value and limit.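

At this double-bonded ring carbon, dimethylcarbamoyl does not keep the activity of compound 2 in this assay, with an at least 3.5-fold higher number from compound 2 to compound 3 (0.54 log units; beyond the scatter). Among the three groups shown, only the one in compound 2 gives a number, while compound 1 and compound 3 both stop at a limit: the limit of > 50000 nM in this assay, at which 2 of the 3 values shown sit.

The step from compound 1 to compound 3 cannot be read, as both values are limits. Still open, on these data alone, is whether an unsubstituted carboxamide, a nitrile or a hydroxymethyl group on this carbon would give a lower number than compound 2.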